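Nitro in Place of Bromo on the Benzoyl Ring

A few compounds are considered here, and "the series" means these few. Any claim that something is new, unique, unknown or untested is made for them only; others in the source may bear on it.

Compound 1 `O=C(/N=C1\NC2(CCCCO2)CCS1)c1ccccc1` is the parent of the set, and in a functional assay on the whole organism (strain CF-1) with Mus musculus as the target, in the writhing test, with a stated time of 15 min (a lower number here means that less compound is needed, a higher number that more compound is needed for the effect), compound 1 gives 5 mg/kg. Compound 2 `COc1ccc(C(=O)/N=C2\NC3(CCCCO3)CCS2)cc1` carries a methoxy group on the aromatic ring, and in this assay compound 2 gives 62 mg/kg. Compound 3 `O=C(/N=C1\NC2(CCCCO2)CCS1)c1ccc(Br)cc1` carries a bromo group instead; in this assay compound 3 reaches only the limit of > 200 mg/kg, so no exact number is known for it. The change from hydrogen to methoxy gave a 12-fold higher number from compound 1 to compound 2 (1.09 log units; beyond the scatter), the change from hydrogen to bromo gave an at least 40-fold higher number from compound 1 to compound 3 (1.60 log units; beyond the scatter), and the change from methoxy to bromo gave an at least 3.2-fold higher number from compound 2 to compound 3 (0.50 log units; beyond the scatter). Compound 4 `O=C(/N=C1\NC2(CCCCO2)CCS1)c1ccc([N+](=O)[O-])cc1` differs from compound 3 by nitro in place of bromo on an aromatic carbon. Every group placed on that aromatic carbon so far has raised the number in this assay, and compound 3 reaches (the limit of > 200 mg/kg in this assay, at which 1 of the 3 values shown sits). Because of an at least 40-fold higher number from compound 1 to compound 3 (1.60 log units; beyond the scatter) and a 12-fold higher number from compound 1 to compound 2 (1.09 log units; beyond the scatter), compound 4 is expected to remain far from compound 1. The step of a number no higher from compound 3 to compound 4 (the limit leaves the size open) is expected to stay within the scatter. Compound 4 is therefore estimated at 200 mg/kg, with a range from 50 mg/kg to 800 mg/kg.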

Compound 4, dose for half-maximal effect: 28 mg/kg
For compound 4 the middle estimate is 7.1-fold (0.85 log units) above the measured one; measured number below the stated range.
By their numbers in this assay, from the lowest: compound 1; then compound 4; then compound 2. At a limit, above all of these: compound 3.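

Nitro in place of bromo shows that a group on this aromatic carbon need not push the number up to the limit in this assay: the change gave an at least 7.1-fold lower number from compound 3 to compound 4 (0.85 log units; beyond the scatter), and nitro in place of methoxy gave a 2.2-fold lower number from compound 2 to compound 4 (0.35 log units; beyond the scatter). Even so, the unsubstituted parent keeps the lowest number of the four, as nitro in place of hydrogen gave a 5.6-fold higher number from compound 1 to compound 4 (0.75 log units; beyond the scatter). As far as these compounds go, the value of compound 3 is a limit, so the true size of its step to nitro stays open: the limit of > 200 mg/kg in this assay, at which 1 of the 4 values shown sits.

From the compounds shown here alone, whether an amine, a carboxylic acid or a fluoro group on this carbon would come closer to compound 1 remains open. The compounds shown also leave open how nitro would fare on another carbon of the same ring.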